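The source may hold more compounds than are shown below. What is called first, only, known or untested is meant among the compounds shown, and "the series" means these compounds.

Measured so far in a functional assay on MCF7 cells (Homo sapiens) for cytotoxicity, read by MTT assay, with a stated time of 24 h; a lower number here means a stronger inhibitor, a higher number a weaker inhibitor
compound 1 `C#CCn1c(=O)c(C=O)cc2cc(OC)ccc21` gives > 100000 nM as a limit
compound 2 `C#CCn1c(=O)c(/C=C/C(=O)/C=C(O)/C=C/c2ccc(O)c(OC)c2)cc2ccccc21` gives 15000 nM as a number
compound 3 `C#CCn1c(=O)c(/C=C/C(=O)/C=C(O)/C=C/c2ccc(O)c(OC)c2)cc2cc(OC)ccc21` gives > 100000 nM as a limit

For compound 3 the reading is the limit of > 100000 nM in this assay, at which 2 of the 3 values shown sit, and no number. Compound 4 `C#CCn1c(=O)c(/C=C/C(=O)/C=C(O)/C=C/c2ccc(O)c(OC)c2)cc2cc(C)ccc21` has methyl in place of methoxy on an aromatic carbon and is otherwise the same. For the measured compounds named here, one measured step bears on this, an at least 6.6-fold higher number from compound 2 to compound 3 (0.82 log units; beyond the scatter) with methoxy in place of hydrogen on an aromatic carbon. Going by the values given here, compound 2 carries hydrogen there and reads 15000 nM as the only number available, so losing the methoxy is expected to lower the number. Methyl is not hydrogen, though, and a limit may be reported again. The step expected in this assay is an at least 2.5-fold lower number from compound 3 to compound 4 (0.39 log units; beyond the scatter) and remains a rough estimate. For compound 4 the estimated value is 40000 nM with an expected range of 12000 nM to 100000 nM as the working figure.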

Compound 4, half-maximal inhibitory concentration: 36200 nM
The estimate for compound 4 lay 1.1-fold (0.04 log units) above the measured number; low and high end bracket the measured number.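

In this assay methyl in place of methoxy gives an at least 2.7-fold lower number from compound 3 to compound 4 (0.44 log units; beyond the scatter) and brings a number back at this position, so a substituent here does not by itself push the reading to the limit. Methyl does not match hydrogen either: it gives a 2.4-fold higher number from compound 2 to compound 4 (0.38 log units; beyond the scatter) and the three groups run hydrogen, methyl, methoxy from lower to higher number. Compound 3 remains a limit, so its step is only a bound: the limit of > 100000 nM in this assay, at which 2 of the 4 values shown sit.

Three groups at one position give an order and no explanation for it. As far as these compounds go, how chlorine, an amine or a longer chain would read at this position remains open.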